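Swapping a Benzyloxy Arm for 2-Chlorophenyl: Cytotoxicity Outlook

This account rests on a few compounds, and the source may have more. Where it says the series, first, only, none or still open, it means among the compounds named here.

Compound 1 `O=C1c2ccccc2N(COCc2ccccc2)S(=O)(=O)N1COCc1ccccc1` was tested in a functional assay on HEL cells (Homo sapiens) for inhibition (on this read-out higher numbers stand for lower toxicity in this test and lower numbers for higher toxicity in this test), where compound 1 gives 130000 nM. Among the three measured compounds this is the only actual number. Compound 2 `O=S1(=O)N=C(OCc2ccccc2)c2ccccc2N1Cc1ccc(Cl)c(Cl)c1` reaches only a limit of the test, and in this assay compound 2 gives > 200000 nM. Compound 3 `O=C1c2ccccc2N(Cc2ccccc2)S(=O)(=O)N1Cc1ccccc1` likewise ends at a limit, and in this assay compound 3 gives > 200000 nM. Compound 1 thus stands alone with a measured number, while the other two sit at the limit of > 200000 nM in this assay, at which 2 of the 3 values shown sit.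

Compound 4 `O=C1c2ccccc2N(Cc2ccccc2Cl)S(=O)(=O)N1COCc1ccccc1` is the unmeasured partner of compound 1. The change is 2-chlorophenyl in place of benzyloxy on a saturated chain carbon bound to a sulfonamide nitrogen in a ring. Among the measured compounds shown here, no two measured compounds differ in exactly one place, so no measured step shows how large such a change tends to be. With all three measured compounds at high concentrations, the expected step from compound 1 to compound 4 is a 1.3-fold higher number from compound 1 to compound 4 (0.12 log units; within the scatter), meaning nothing beyond the usual scatter. For compound 4 the expected result in this assay is 170000 nM, with a range from 70000 nM to 400000 nM, and a limit rather than a number is quite possible.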

Compound 4, half-maximal cytotoxic concentration: > 50000 nM
Compound 4: a limit, no number (the forecaster's own chance of this, stated with the estimate: 50%); the middle value lies beyond the limit too.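

In this assay compound 4 gives > 50000 nM, which is a limit of the test and not a number. The step from compound 1 to compound 4 therefore cannot be read. The compounds shown leave open whether 2-chlorophenyl in place of benzyloxy changes the result in this assay at all.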